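The source may hold more compounds than are shown below. What is called first, only, known or untested is meant among the compounds shown, and "the series" means these compounds.

In a physicochemical assay for solubility (a higher number here means a more soluble compound, a lower number a less soluble compound), compound 3 (`CNC(=O)c1cc(C(=O)NC)n([C@@H](C)c2ccccc2)n1`) stands at >= 88 ug/mL, which is a limit and not a number. Compound 2 (`CNC(=O)c1cc(C(=O)N[C@H]2CC[C@H](OC)CC2)n([C@@H](C)c2ccccc2)n1`) also gives only a limit, >= 161 ug/mL. Compound 1 (`CNC(=O)c1cc(C(=O)NC2CCOCC2)n([C@@H](C)c2ccccc2)n1`) is the only one of the three with a measured number, 31 ug/mL.

Compound 4 (`CNC(=O)c1cc(C(=O)NC2CC2)n([C@@H](C)c2ccccc2)n1`) has cyclopropyl in place of methyl on an amide-type nitrogen.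

Three measured steps change the same amide-type nitrogen. Replacing oxan-4-yl with methyl gives an at least 2.8-fold higher number from compound 1 to compound 3 (0.45 log units; beyond the scatter), and replacing it with 4-methoxycyclohexyl gives an at least 5.1-fold higher number from compound 1 to compound 2 (0.71 log units; beyond the scatter). Both are at least modest and both start from compound 1, so they show how low the number can fall with a different group at this place. The third step, a step that the two limits leave unreadable from compound 2 to compound 3, cannot be sized. The heavy-atom count of the group does not order these compounds, as compound 2 keeps a limit with a larger group than compound 1 has. Among the measured compounds shown here, no measured step tests cyclopropyl itself, so no step beyond the scatter is expected, with any drift more likely downward towards compound 1. The expected change is an at least 1.0-fold lower number from compound 3 to compound 4 (0.01 log units; that floor lies within the scatter). For compound 4 the estimated value in this assay is 85 ug/mL, with an expected range of 35 ug/mL to 200 ug/mL.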

Compound 4, solubility: >= 165 ug/mL
Compound 4 gave a limit, no number; the forecaster's own chance of this, stated with the estimate: 35%; middle value at least 1.9-fold (0.28 log units) from the limit.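

In this assay compound 4 gives >= 165 ug/mL, which is a limit of the assay and not a number. Cyclopropyl in place of oxan-4-yl on the amide-type nitrogen gives an at least 5.3-fold higher number from compound 1 to compound 4 (0.72 log units; beyond the scatter), so cyclopropyl joins methyl and 4-methoxycyclohexyl as a third group at this place that steps beyond the scatter from compound 1. Compound 1 is now the only one of the four with a measured number, and neither a ring in the group nor its heavy-atom count separates it from the others: cyclopropyl also brings a ring, and 4-methoxycyclohexyl is the larger group; the steps from compound 3 to compound 4 and from compound 2 to compound 4 cannot be read, as limits stand at both ends.

From the compounds shown here alone, how far compounds 2, 3 and 4 really lie beyond their limits stays open, so no order among methyl, cyclopropyl and 4-methoxycyclohexyl can be drawn. Also open, going by these compounds, is whether an aminoethyl group or a longer alkyl chain on this amide-type nitrogen would end in a limit too or fall towards compound 1.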